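A 4-chlorophenyl for methyl swap, tested twice

A few compounds are considered here, and "the series" means these few. Any claim that something is new, unique, unknown or untested is made for them only; others in the source may bear on it.

Compound 2 `COc1ccc(CNC(=O)CSc2nc3ccc(NC(C)=O)cc3s2)cc1` carries an acetamido group and a 4-methoxybenzyl amide. In a functional assay on HepG2 cells (Homo sapiens) for cytotoxicity, read by MTT assay, with a stated time of 48 h (a higher number here means a weaker inhibitor, a lower number a stronger inhibitor), compound 2 gives 11200 nM. Compound 1 `COc1ccc(CNC(=O)CSc2nc3ccc(NC(=O)c4ccc(Cl)cc4)cc3s2)cc1` differs from it by 4-chlorophenyl in place of methyl on a carbonyl carbon, and in this assay compound 1 gives 7400 nM; the step is a 1.5-fold lower number from compound 2 to compound 1 (0.18 log units; within the scatter).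

Compound 3 `CNC(=O)CSc1nc2ccc(NC(C)=O)cc2s1` keeps the acetamido group but differs from compound 2 by hydrogen in place of 4-methoxyphenyl on a saturated chain carbon bound to an amide-type nitrogen. For compound 3 in this assay only a limit is reported, > 100000 nM, which is the limit of > 100000 nM in this assay, at which 1 of the 3 values shown sits. That step is an at least 8.9-fold higher number from compound 2 to compound 3 (0.95 log units; beyond the scatter).

For the measured compounds named here, compound 4 `CNC(=O)CSc1nc2ccc(NC(=O)c3ccc(Cl)cc3)cc2s1`, not yet measured, differs from compound 3 by 4-chlorophenyl in place of methyl on a carbonyl carbon, the same change in the same place as the one from compound 2 to compound 1. Because that earlier step was a 1.5-fold lower number from compound 2 to compound 1 (0.18 log units; within the scatter), a similarly small step is expected here, a step that the limit leaves unreadable from compound 3 to compound 4. Compound 4 is therefore expected to give about 120000 nM in this assay, with a fair chance that again only a limit is reported.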

Compound 4, half-maximal inhibitory concentration: 15300 nM
The estimate for compound 4 lay 7.8-fold (0.89 log units) above the measured number; measured number outside the range, below it.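

In this assay, 4-chlorophenyl in place of methyl on a carbonyl carbon gives an at least 6.5-fold lower number from compound 3 to compound 4 (0.81 log units; beyond the scatter), so the change does not carry over at one size from one core to the other: the same change on two cores in this assay, a 1.5-fold lower number (0.18 log units; within the scatter) from compound 2 to compound 1 and an at least 6.5-fold lower number (0.81 log units; beyond the scatter) from compound 3 to compound 4, at least 4.3-fold (0.63 log units) apart, beyond the scatter of two such steps. Hydrogen in place of 4-methoxyphenyl gives a 2.1-fold higher number from compound 1 to compound 4 (0.32 log units; beyond the scatter), and this change also depends on its partner group: the same change on two cores in this assay, an at least 8.9-fold higher number (0.95 log units; beyond the scatter) from compound 2 to compound 3 and a 2.1-fold higher number (0.32 log units; beyond the scatter) from compound 1 to compound 4, at least 4.3-fold (0.63 log units) apart, beyond the scatter of two such steps. Compound 3 is given only as a limit, > 100000 nM, so the full size of these gaps stays unknown, and two cores show neither a general rule nor a reason for the difference.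

Still open, on these data alone, is how a longer chain or a carboxylic acid in place of the 4-chlorophenyl on the carbonyl carbon would behave on either core.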